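The compounds below may be only part of what the source reports. "The series", "measured", "known", "first", "only" and "open" are said of these compounds alone.

Measured compounds:
compound 1, `CC1=C(C(=O)C2CC2)C(c2cccs2)NC(=O)N1`, which in an assay on membranes from HEK293 cells for displacement of a labelled ligand from adenosine receptor A2b (Homo sapiens), read by scintillation counting, with a stated time of 30 min, tested at 1 uM (a higher number here means more inhibition at the concentration tested (going by the name of the read-out), a lower number less inhibition), gives 1%
compound 2, `CCC(C)OC(=O)C1=C(C)NC(=O)NC1c1cccs1`, which in this assay gives 7%

Compound 2 stands next to compound 1 on these numbers: the step of a number 6 percentage points higher from compound 1 to compound 2 (within the scatter) is within the scatter, so the two values cannot be told apart and the inhibition in this assay is level between the two compounds.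

Compound 3, `CC1=C(C(=O)OC2CCCCC2)C(c2cccs2)NC(=O)N1`, has not been measured in this assay. It differs from compound 2 in one place: cyclohexyl in place of sec-butyl on an oxygen next to a carbonyl group. For the measured compounds named here, the only measured step that bears on this change is the one from compound 1 to compound 2, where the group on the carbonyl carbon was exchanged and the read-out in this assay moved by a number 6 percentage points higher from compound 1 to compound 2 (within the scatter), within the scatter. Both measured compounds sit at the low end of the scale. An exchange of one group on the oxygen next to the carbonyl for another is therefore expected to leave the number close to where compound 2 stands, with a step of no change at the digits printed from compound 2 to compound 3 (within the scatter) that is not expected to exceed the scatter. Compound 3 is estimated at 7% in this assay, with a range from 0% to 17%.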

Compound 3, a percentage reported as inhibition, at one concentration (the size of the read-out at that concentration, not a potency): 3%
For compound 3 the middle estimate is 4 percentage points above the measured one; low and high end bracket the measured number.
By their numbers in this assay, from the lowest: compounds 1, 3 and 2 (each within the scatter of the next).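

In this assay, the group on the oxygen next to a carbonyl group is now varied directly, which the earlier pair did not do, and exchanging the ringless sec-butyl for the ring-bearing cyclohexyl gives a number 4 percentage points lower from compound 2 to compound 3 (within the scatter), so on these numbers the ring and the larger group make no difference that can be told from the scatter. Cyclohexyloxy in place of cyclopropyl on a carbonyl carbon gives a number 2 percentage points higher from compound 1 to compound 3 (within the scatter), so the larger exchange at this position also leaves the values level, and no compound of the three stands apart from the others. No measurement is available that would explain these results or say anything about how these groups act at the receptor.

Going by these compounds, all the groups compared here consist of carbon alone beyond the linking oxygen, so it remains open whether a longer chain ending in an amine, or a free carboxylic acid at this position, would lift the inhibition clear of the scatter. The compounds shown also leave open whether changes elsewhere on the shared core would move the number at all.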